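A Hydroxypropyl Chain on the Sulfur of Compound 3

The source may hold more compounds than are shown below. What is called first, only, known or untested is meant among the compounds shown, and "the series" means these compounds.

Measured compounds:
- compound 1, `CSc1nc(NCc2ccc(-c3ccccn3)cc2)c2[nH]nc(C(C)C)c2n1`, 783 nM
- compound 2, `CNCCSc1nc(NCc2ccc(-c3ccccn3)cc2)c2[nH]nc(C(C)C)c2n1`, 56 nM
- compound 3, `CC(C)c1n[nH]c2c(NCc3ccc(-c4ccccn4)cc3)nc(S)nc12`, 2760 nM

Compound 3 gives the highest number of the three in a functional assay on HT cells (Homo sapiens) for antiproliferative activity, read by fluorescence, with a stated time of 72 h; on this read-out lower numbers stand for stronger inhibition of growth and higher numbers for weaker inhibition of growth: compound 1 sits nearest, and compound 2 furthest, both beyond the scatter. Compound 4, `CC(C)c1n[nH]c2c(NCc3ccc(-c4ccccn4)cc3)nc(SCCCO)nc12`, differs from compound 3 at the sulfur: 3-hydroxypropyl in place of hydrogen on a sulfur.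

Among the compounds with values here, two measured steps bear on this change, both read in reverse. The step of a 3.5-fold higher number from compound 1 to compound 3 (0.55 log units; beyond the scatter) shows that the bare hydrogen gives a modestly higher number than a methyl on the sulfur. The step of a 49-fold higher number from compound 2 to compound 3 (1.69 log units; beyond the scatter) shows a large rise when a longer chain that carries an amine is replaced by the bare hydrogen. The 3-hydroxypropyl group is a chain of four heavy atoms like that of compound 2, but it ends in a hydroxyl rather than an amine, so the gain is expected to lie between the two.

Compound 4 is therefore expected to show a 7.9-fold lower number from compound 3 to compound 4 (0.90 log units; beyond the scatter) in this assay. The estimate for compound 4 is 350 nM, with a range from 110 nM to 1100 nM.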

Compound 4, concentration for 50% growth inhibition: 109 nM
For compound 4 the middle estimate is 3.2-fold (0.51 log units) above the measured one; the measured number lies below the stated range.
By their numbers in this assay, from the lowest: compounds 2 and 4 (each within the scatter of the next); then compound 1; then compound 3.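

In this assay the 3-hydroxypropyl chain on the sulfur gives a 25-fold lower number from compound 3 to compound 4 (1.40 log units; beyond the scatter) and so shows that a large drop at this position does not depend on a chain that carries an amine. The hydroxyl-ended chain and the amine-bearing chain cannot be ranked against each other, since the comparison gives a 1.9-fold higher number from compound 2 to compound 4 (0.29 log units; within the scatter) and that gap stays within the scatter. The new chain also goes clearly past a plain methyl on the sulfur, as a 7.2-fold lower number from compound 1 to compound 4 (0.86 log units; beyond the scatter) shows, so at this position the gain is tied to a chain and is not reached by filling the sulfur with methyl alone.

The compounds shown leave open how a shorter 2-hydroxyethyl chain, a longer chain, or a chain ending in a carboxylic acid or a methyl ether would compare with compound 4 in this assay and whether the end of the chain matters at all at other lengths. Nothing available accounts for the size of these drops in the number or for the match between the two chains.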